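Solubility notes on the cyclohexylcarbonyl analogue of compound 2

A few compounds are considered here, and "the series" means these few. Any claim that something is new, unique, unknown or untested is made for them only; others in the source may bear on it.

Measured so far in a physicochemical assay for solubility, read by HPLC, at pH 6.8; a lower number here means a less soluble compound, a higher number a more soluble compound:
- compound 1 `CC(C)(C)c1cc(NC(=O)[C@@H]2CCCCN2Cc2ccc(Cl)cc2)no1` gives only a limit, < 0.1 ug/mL.
- compound 2 `CC(C)(C)c1cc(NC(=O)[C@@H]2CCCCN2C(=O)c2ccc(Cl)cc2)no1` gives only a limit, < 0.1 ug/mL.

Compound 2 stands at the limit of this assay, where both measured values sit (the limit of < 0.1 ug/mL in this assay, at which 2 of the 2 values shown sit). Among the compounds with values here, the one measured step, a step that the two limits leave unreadable from compound 1 to compound 2, is unreadable. Compound 3 `CC(C)(C)c1cc(NC(=O)[C@@H]2CCCCN2C(=O)C2CCCCC2)no1` differs from compound 2 by cyclohexyl in place of 4-chlorophenyl on a carbonyl carbon. Within the data shown here, no measured step bears on this change, so the direction of an at least 1.5-fold higher number from compound 2 to compound 3 (0.17 log units; that floor lies within the scatter) is unconstrained and the estimate is held close to the limit. Compound 3 is expected to give about 0.15 ug/mL, within 0.05 ug/mL to 1 ug/mL.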

Compound 3, solubility: 6.4 ug/mL
For compound 3 the middle estimate is 43-fold (1.63 log units) below the measured one, outside the stated range (above it).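

In this assay, cyclohexyl in place of 4-chlorophenyl on a carbonyl carbon gives an at least 64-fold higher number from compound 2 to compound 3 (1.80 log units; beyond the scatter), the first sign that this position can lift the read-out clear of the limit. Cyclohexylcarbonyl in place of 4-chlorobenzyl on an amine nitrogen in a ring gives an at least 64-fold higher number from compound 1 to compound 3 (1.80 log units; beyond the scatter). Only compound 3 stands clear of the limit, and the step between the other two compounds cannot be read: the limit of < 0.1 ug/mL in this assay, at which 2 of the 3 values shown sit.

The change removes both the chlorine and the aromatic ring, and the compounds shown do not separate the two. Plain phenyl or 4-chlorocyclohexyl on the same carbonyl carbon would separate them.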